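The source may hold more compounds than are shown below. What is called first, only, known or untested is meant among the compounds shown, and "the series" means these compounds.

Compound 1, with the structure `C=C1C(=O)[C@]23C[C@@]1(O)CC[C@H]2c1ccc(O)c(C)c1[C@@H]3Cn1cc(-c2ccccc2)nn1`, bears a phenyl group on the triazole ring of the shared core. In a functional assay on A549 cells (Homo sapiens) for cytotoxicity, read by MTT assay, with a stated time of 4 days (a higher number here means a weaker inhibitor, a lower number a stronger inhibitor), compound 1 gives 1160 nM. For the measured compounds named here, the only other measured compound, compound 2, with the structure `C=C1C(=O)[C@]23C[C@@]1(O)CC[C@H]2c1ccc(OS(=O)(=O)c2ccc(C)cc2)c(C)c1[C@@H]3Cn1cc(-c2ccc(C)cc2)nn1`, carries a tosylate on the phenol oxygen and a methyl group on the phenyl ring; in this assay compound 2 gives 1830 nM. The two numbers lie within the usual scatter of each other, so compound 1 and compound 2 cannot be told apart on these data.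

Compound 3, with the structure `C=C1C(=O)[C@]23C[C@@]1(O)CC[C@H]2c1ccc(O)c(C)c1[C@@H]3Cn1cc(-c2ccc(Br)cc2)nn1`, keeps the free phenol and differs from compound 1 in one place: bromo in place of hydrogen on an aromatic carbon. Going by the values given here, no step between measured compounds shows what such a change does in this assay. With nothing to point either way, the step of a 1.2-fold lower number from compound 1 to compound 3 (0.09 log units; within the scatter) is expected to stay within the scatter, with no change that could be told from noise. Compound 3 is therefore estimated to give 950 nM in this assay, with a range from 400 nM to 2500 nM.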

Compound 3, half-maximal inhibitory concentration: 1140 nM
Compound 3: middle estimate off by 1.2-fold (0.08 log units), on the low side; the measured number falls inside the stated range.
By their numbers in this assay, from the lowest: compounds 3, 1 and 2 (each within the scatter of the next).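

For the compounds shown here, this is the first step between measured compounds that differ in one place: changing phenyl to 4-bromophenyl, with bromo on an aromatic carbon of a six-membered aromatic ring of carbon only, para to a large group, gives a 1.0-fold lower number from compound 1 to compound 3 (0.01 log units; within the scatter) in this assay and so cannot be told from noise. This position therefore accepts a bromine atom in place of hydrogen with the free phenol kept, and the read-out shows no change that stands out from repeated measurement. No accompanying measurement bears on this result, so the data offer no explanation for it.

From the compounds shown here alone, a single atom at a single position says little about other groups there, and it remains open whether an amine, a carboxylic acid or a longer chain in the same place would move the number beyond the scatter. Compound 2 differs from compound 1 in two places at once, the tosylate on the phenol oxygen and the methyl group on the phenyl ring, so what the phenol oxygen contributes on its own also stays unresolved.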